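A few compounds are considered here, and "the series" means these few. Any claim that something is new, unique, unknown or untested is made for them only; others in the source may bear on it.

Within the data shown here, in an ADME assay on the whole organism (Rattus norvegicus) for pharmacokinetics, using cassette dosing, at a dose of 1 mg/kg by the oral route (a higher number here means that a larger share of the oral dose reaches the circulation, a lower number that a smaller share of the oral dose reaches the circulation), compound 1 `C[C@@H](Cn1c(=O)[nH]/c(=N\c2ccc(Oc3ccc(F)cn3)cc2)n(Cc2ccc(Cl)cc2)c1=O)C(=O)O` gives 82.4% and compound 2 `C[C@@H](Cn1c(=O)[nH]/c(=N\c2ccc(Oc3cnccn3)cc2)n(Cc2ccc(Cl)cc2)c1=O)C(=O)O` gives 56.5% as the lower of the two numbers so far. Compound 3 `C[C@@H](Cn1c(=O)[nH]/c(=N\c2ccc(Oc3cccc(F)n3)cc2)n(Cc2ccc(Cl)cc2)c1=O)C(=O)O` has not yet been measured. The structural change from compound 2 to compound 3 is this (6-fluoropyridin-2-yl in place of pyrazin-2-yl on an oxygen on an aromatic ring): 6-fluoropyridin-2-yl in place of pyrazin-2-yl on an oxygen on an aromatic ring. Among the measured compounds shown here, the only measured step that bears on it is a number 25.9 percentage points lower from compound 1 to compound 2 (beyond the scatter) with pyrazin-2-yl in place of 5-fluoropyridin-2-yl, so a rise of somewhat smaller size is expected here. For the measured compounds named here, compound 3 does not carry the 5-fluoropyridin-2-yl group of compound 1, and no measurement yet covers the 6-fluoropyridin-2-yl group. The expected step is a number 14.5 percentage points higher from compound 2 to compound 3 (beyond the scatter) on this reading. For compound 3 the estimated value is 71% with a range from 50% to 90% as its expected span.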

Compound 3, oral bioavailability: 60%
The estimate for compound 3 lay 11 percentage points above the measured number; the measured number falls inside the stated range.
By their numbers in this assay, from the lowest: compounds 2 and 3 (each within the scatter of the next); then compound 1.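

In this assay, a fluorine on the pyridine is not enough to hold the number of compound 1: with 6-fluoropyridin-2-yl in place of 5-fluoropyridin-2-yl on the same oxygen, the record shows a number 22.4 percentage points lower from compound 1 to compound 3 (beyond the scatter) and so the two isomeric groups are not interchangeable here. Against the pyrazin-2-yl group, the 6-fluoropyridin-2-yl group gives a number 3.5 percentage points higher from compound 2 to compound 3 (within the scatter) and so the two cannot be told apart in this read-out, despite their different ring atoms, leaving the 5-fluoropyridin-2-yl group alone at the higher level among these three compounds. Nothing available accounts for this difference between the groups.

Going by these compounds, whether an unsubstituted pyridin-2-yl, a 5-chloropyridin-2-yl or a 5-methoxypyridin-2-yl group on this oxygen would stand with compound 1 or with compounds 2 and 3 remains open. Also open, on these data alone, is whether the same gap between the groups would persist if the carboxylic acid were replaced by an amide.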